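This account rests on a few compounds, and the source may have more. Where it says the series, first, only, none or still open, it means among the compounds named here.

The compounds described here share one core, which stands beside each structure, and all were tested in a functional assay on MDA-MB-231 cells (Homo sapiens) for cytotoxicity, read by MTT assay, with a stated time of 48 h; a lower number here means a stronger inhibitor, a higher number a weaker inhibitor. Compound 1 `O=c1ccoc2cc(OCc3cn(Cc4cccc(Br)c4)nn3)ccc12` returns only a limit of the assay in this assay, namely > 100000 nM, so its potency is not known as a number. Compound 2 `CC(C)(C)c1ccc(Cn2cc(COc3ccc4c(=O)ccoc4c3)nn2)cc1` likewise gives only a limit in this assay, > 100000 nM. Compound 3 `C#CCOc1ccc2c(=O)ccoc2c1`, the smallest of the three, also reaches only a limit, > 100000 nM. For the measured compounds named here, every measured value thus sits at the same limit, (the limit of > 100000 nM in this assay, at which 3 of the 3 values shown sit), and no step between two measured compounds can be drawn: nothing separates them in the numbers.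

Compound 4 `O=c1ccoc2cc(OCc3cn(Cc4cccc(Cl)c4)nn3)ccc12` is the unmeasured partner of compound 1. Its difference from compound 1 is chloro in place of bromo on an aromatic carbon. Going by the values given here, because the three measured values all sit at the limit of > 100000 nM in this assay, at which 3 of the 3 values shown sit, there is no measured step by which to size this change; the expectation is that the step that the limit leaves unreadable from compound 1 to compound 4 amounts to nothing beyond the scatter. Compound 4 is therefore expected to give about 150000 nM in this assay, with a range from 50000 nM to 500000 nM, most probably reported once more as a limit rather than as a number.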

Compound 4, half-maximal inhibitory concentration: > 100000 nM
Compound 4 ended at the assay's limit; the forecaster's own chance of this, stated with the estimate: 85%; the middle value is on the limit's open side.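

Compound 1 and compound 4 both return only a limit of the assay, not a number, so no step can be read for chloro in place of bromo: the limit of > 100000 nM in this assay, at which 4 of the 4 values shown sit. The compounds shown leave open whether a result in this assay can be had as a number rather than a limit for any compound with the shared core.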